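The source may report more compounds than this note shows. Statements on the series, on what has been measured and on what is new or still open speak of the compounds shown alone.

Measured so far:
compound 1 `COc1cccc(C2=CCN(S(=O)(=O)N3CCCC[C@@H]3C(=O)NO)CC2)c1` — 260 nM
compound 2 `O=C(NO)[C@H]1CCCCN1S(=O)(=O)N1CC=C(c2ccc(-c3ccccc3)cc2)CC1` — 19000 nM

In a functional assay on MONO-MAC-6 cells (Homo sapiens) for inhibition (a lower number here means a stronger inhibitor, a higher number a weaker inhibitor), compound 2 gives 19000 nM, the higher of the two numbers in hand, and compound 1 with 260 nM stands far lower, a gap well beyond the scatter of repeated measurements. Compound 3 `CCCc1ccc(C2=CCN(S(=O)(=O)N3CCCC[C@@H]3C(=O)NO)CC2)cc1` has not been measured. Its relation to compound 2 is the change (propyl in place of phenyl on an aromatic carbon), that is, propyl in place of phenyl on an aromatic carbon of the six-membered ring of carbon only, para to a large group. Within the data shown here, no measured pair shows this exact change, so the step can only be judged from the two values: the smaller aromatic substituent in compound 1 goes with a much lower number, and the shorter group entering in compound 3 is expected to move the number down rather than up. For compound 3 the step from compound 2 is expected to be a 9.5-fold lower number from compound 2 to compound 3 (0.98 log units; beyond the scatter). Compound 3 is estimated at 2000 nM, within 400 nM to 10000 nM.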

Compound 3, half-maximal inhibitory concentration: 2600 nM
Beside the measured number, compound 3's estimate is 1.3-fold (0.11 log units) below it, within the range that was stated.
By their numbers in this assay, from the lowest: compound 1; then compound 3; then compound 2.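

In this assay, among these compounds, propyl in place of phenyl on the aromatic carbon para to a large group gives a 7.3-fold lower number from compound 2 to compound 3 (0.86 log units; beyond the scatter) and provides the first single-place reading at this position: the group carried there changes the number beyond the scatter. The change does not bring the series back to the level of compound 1, since 4-propylphenyl in place of 3-methoxyphenyl on the double-bonded ring carbon gives a 10-fold higher number from compound 1 to compound 3 (1.00 log units; beyond the scatter) and the aryl group as a whole therefore still matters. Nothing available explains either step.

Two compounds with different groups at this carbon cannot show whether the number follows chain length, so a butyl chain or an ethyl group would be informative. A carboxylic acid or an amine at the same carbon would test whether a non-hydrocarbon group is tolerated there.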